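Cytotoxicity notes on a pyrazole-linked triazolopyrimidine series

This account rests on a few compounds, and the source may have more. Where it says the series, first, only, none or still open, it means among the compounds named here.

Measured so far:
compound 1, `Cc1cc(Nc2cc(-c3ccc(Cl)cc3)[nH]n2)n2nc(SCc3ccc(Br)cc3)nc2n1`: 28200 nM
compound 2, `Cc1cc(Nc2ccn(Cc3nc(C)c4ccccc4n3)n2)n2nc(SCc3ccc(Br)cc3)nc2n1`: 36800 nM

In an ADME assay on GES1 cells (Homo sapiens) for inhibition, read by MTT assay, with a stated time of 72 h (a higher number here means a weaker inhibitor, a lower number a stronger inhibitor), compound 1 gives 28200 nM and compound 2 gives 36800 nM. Compound 1 holds the lower of the two numbers, but the gap to compound 2 lies within the scatter, so the two compounds are read as alike in this assay. Among the compounds with values here, both carry the same shared core and the same (4-bromophenyl)methylsulfanyl group; they differ at the pyrazole and its substituent, and no single-point step between them is available.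

Compound 3, `Cc1cc(Nc2cc(-c3cccs3)[nH]n2)n2nc(SCc3ccc(Br)cc3)nc2n1`, is not yet measured. It follows from compound 1 by one change: thiophen-2-yl in place of 4-chlorophenyl on an aromatic carbon. The change swaps one aromatic ring for another on the same aromatic carbon, leaving the rest of the molecule as in compound 1. Within the data shown here, with only two measured compounds, both sitting close together in this assay, there is no basis for a step beyond the scatter in either direction. The step from compound 1 to compound 3 is expected to be a 1.1-fold higher number from compound 1 to compound 3 (0.03 log units; within the scatter). For compound 3 the estimate is 30000 nM, with a range from 12000 nM to 75000 nM.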

Compound 3, half-maximal inhibitory concentration: 38700 nM
Estimate against measurement, compound 3: 1.3-fold (0.11 log units) below, and the stated range covers the measured number.
By their numbers in this assay, from the lowest: compounds 1, 2 and 3 (each within the scatter of the next).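

Within the data shown here, the first single-place step at this position is the exchange of 4-chlorophenyl for thiophen-2-yl on an aromatic carbon of the five-membered aromatic ring with 2 nitrogen. In this assay, it gives a 1.4-fold higher number from compound 1 to compound 3 (0.14 log units; within the scatter), so compound 1 and compound 3 are read as alike. One six-membered aromatic ring of carbon only can thus give way at this carbon to one five-membered aromatic ring with 1 hetero atom without a step beyond the scatter, a point the unpaired comparison of compound 1 and compound 2 could not settle. Nothing at hand bears on why this step has the size it has.

The compounds shown leave open whether this position tolerates only aromatic rings, since a step from 4-chlorophenyl to a basic amine such as a piperidine, to a carboxylic acid or to a longer alkyl chain could behave differently in this assay. They also leave open whether an exchange of the (4-bromophenyl)methylsulfanyl group, for example for a plain methylsulfanyl group, would move the number beyond the scatter.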